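The compounds below may be only part of what the source reports. "The series", "measured", "known", "first", "only" and "open" are said of these compounds alone.

Working notes on the series. Compound 1 `C=C1CC[C@@H]2[C@](C)(CO)[C@H](O)CC[C@@]2(C)[C@@H]1C/C=C(/C(=O)O)[C@H](O)CO` opens the set. In a functional assay on BMMC cells (Mus musculus, strain C57BL/6) for inhibition, with stated times of 5 days and 48 h (on this read-out higher numbers stand for weaker inhibition and lower numbers for stronger inhibition), compound 1 returns > 30000 nM, which is a limit of the assay and not a number; this is the case noted in the limit of > 30000 nM in this assay, at which 1 of the 2 values shown sits. Compound 2 `C=C1CC[C@@H]2[C@](C)(CNCc3ccc(OC)cc3)[C@H](O)CC[C@@]2(C)[C@@H]1/C=C/C1=CCOC1=O` carries the 4-methoxybenzyl group on the shared core. In this assay, going by the values given here, compound 2 gives 750 nM, the only number measured so far, so compound 2 stands alone as the reference point of the series. Compound 3 `C=C1CC[C@@H]2[C@](C)(CNCc3ccc(OC)c(OC)c3)[C@H](O)CC[C@@]2(C)[C@@H]1/C=C/C1=CCOC1=O` is the next member to be run. The change from compound 2 is methoxy in place of hydrogen on an aromatic carbon. Among the compounds with values here, no step between two measured compounds is available to weigh a change of this kind. The expected step of a 1.1-fold lower number from compound 2 to compound 3 (0.03 log units; within the scatter) is none beyond the usual scatter, with no direction favoured. Compound 3 is estimated at 700 nM, with a range from 300 nM to 1600 nM.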

Compound 3, half-maximal inhibitory concentration: 3740 nM
Beside the measured number, compound 3's estimate is 5.3-fold (0.73 log units) below it, outside the stated range (above it).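

In this assay the series now has its first readable single change, and it goes towards weaker inhibition: a 5.0-fold higher number from compound 2 to compound 3 (0.70 log units; beyond the scatter) on going from the 4-methoxybenzyl to the 3,4-dimethoxybenzyl group. The aromatic carbon ortho to a methoxy group and meta to a large group is therefore not indifferent to substitution, since methoxy in place of hydrogen there moves the number beyond the usual scatter. Nothing measured here accounts for the size or direction of this step.

On these data alone, this is a single step at a single position, so it remains open whether the loss belongs to methoxy itself or would also follow from a fluorine atom, a hydroxyl or an ethoxy group on the same carbon. As far as these compounds go, how an amine or a carboxylic acid would read there also remains open.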